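The source may report more compounds than this note shows. Statements on the series, on what has been measured and on what is new or still open speak of the compounds shown alone.

Measured so far:
compound 1 `ClCc1ccc(Cn2cnc3c(Cl)ncnc32)cc1` — 15900 nM
compound 2 `ClCc1ccccc1Cn1cnc2c(Cl)nc(Cl)nc21` — 6450 nM

Both were tested in a functional assay on MDA-MB-435 cells (Homo sapiens) for cytotoxicity, read by sulforhodamine B assay, with a stated time of 48 h; on this read-out lower numbers stand for higher toxicity in this test and higher numbers for lower toxicity in this test. Compound 2 gives the lowest of the two numbers; its nearest neighbour, compound 1, sits higher by a margin beyond the scatter. Compound 3 `ClCc1ccccc1Cn1cnc2c(Cl)ncnc21` differs from compound 2 in one place: hydrogen in place of chloro on an aromatic carbon. Among the compounds with values here, no pair of measured compounds shows this change on its own, so its size is not fixed; a moderate rise in the number, toward lower toxicity, is expected. Compound 3 is therefore estimated at 12000 nM, with a range from 4000 nM to 35000 nM, which is the expected step of a 1.9-fold higher number from compound 2 to compound 3 (0.27 log units; within the scatter).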

Compound 3, concentration lethal to 50% of the cells: 36300 nM
Compound 3: the middle estimate sits 3.0-fold (0.48 log units) below what was measured; measured number outside the range, above it.
By their numbers in this assay, from the lowest: compound 2; then compound 1; then compound 3.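

In this assay, hydrogen in place of chloro on the aromatic carbon between two ring nitrogen atoms gives a 5.6-fold higher number from compound 2 to compound 3 (0.75 log units; beyond the scatter) and so lies beyond the scatter. This shows that the substituent at this position affects the read-out, with the chloro compound 2 the more toxic in this test. Nothing available explains the size of this step. As far as these compounds go, only chloro and hydrogen are compared at this carbon, so it remains open how an amine, a methoxy group or a longer chain there would read.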